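The compounds below may be only part of what the source reports. "The series", "measured", "known", "first", "only" and "open" are said of these compounds alone.

Measured so far in an assay on isolated protein for inhibition of sulfide:quinone oxidoreductase, mitochondrial (Homo sapiens); on this read-out higher numbers stand for weaker inhibition and lower numbers for stronger inhibition:
compound 1 `COc1cccc(-c2cc(-c3ccc(F)cc3)c(C#N)c(OC)n2)c1` gives 108 nM
compound 2 `COc1ccccc1-c1cc(-c2ccc(F)cc2)c(C#N)c(OC)n1` gives 75 nM
compound 3 `N#Cc1c(-c2ccccc2)cc(-c2ccccc2)nc1OCc1ccccc1` gives 100 nM

Compound 2 carries the lowest of the three numbers, but its separation from compound 3 and from compound 1 stays within the usual scatter, so the three compounds read as equivalent on this read-out.

The next compound, compound 4 `COc1nc(-c2ccncc2)cc(-c2ccc(F)cc2)c1C#N`, differs from compound 2 in one place: pyridin-4-yl in place of 2-methoxyphenyl on an aromatic carbon. For the measured compounds named here, the only measured step at this position is a 1.4-fold lower number from compound 1 to compound 2 (0.16 log units; within the scatter), which exchanged one methoxyphenyl for another without a change beyond the scatter. Going by the values given here, no measured pair replaces a ring of carbon only by a ring with one hetero atom, so the effect of the pyridin-4-yl group is not covered by the series; compound 3 and compound 2 sit close in number, which shows only that variation elsewhere on the shared core has so far produced small shifts. The expectation for this assay is therefore a step of modest size, direction open, with a wide range to reflect the missing precedent. Compound 4 is estimated at 150 nM, range 40 nM to 600 nM. That estimate means an expected 2.0-fold higher number from compound 2 to compound 4 (0.30 log units; within the scatter), within or near the scatter.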

Compound 4, half-maximal inhibitory concentration: 17400 nM
Beside the measured number, compound 4's estimate is 120-fold (2.06 log units) below it; the whole stated range lies below it.
By their numbers in this assay, from the lowest: compounds 2, 3 and 1 (each within the scatter of the next); then compound 4.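

In this assay this position proves far from indifferent: pyridin-4-yl in place of 2-methoxyphenyl gives a 230-fold higher number from compound 2 to compound 4 (2.37 log units; beyond the scatter), and pyridin-4-yl in place of 3-methoxyphenyl gives a 160-fold higher number from compound 1 to compound 4 (2.21 log units; beyond the scatter), whereas the exchange of one methoxyphenyl for the other gave only a 1.4-fold lower number from compound 1 to compound 2 (0.16 log units; within the scatter). The two methoxyphenyl groups thus read as equivalent, while the change to pyridin-4-yl, the only one here that alters the ring itself, weakens inhibition far beyond the scatter, and it both removes the methoxy group and brings in a ring with one hetero atom. Nothing available explains the size of this step.

The compounds shown do not separate the contribution of the ring nitrogen from that of the departed methoxy group, and a methoxy-substituted pyridine ring at this position would bear directly on that. As far as these compounds go, it also stays open how far the result depends on where the ring nitrogen sits, as a pyridin-3-yl group would show, and whether a thiophene ring or a saturated ring such as piperidine would read closer to compound 2 or to compound 4.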